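Moving the bromo group: expected cytotoxicity of compound 4

This account rests on a few compounds, and the source may have more. Where it says the series, first, only, none or still open, it means among the compounds named here.

In an ADME assay on SH-SY5Y cells (Homo sapiens) for cytotoxicity, read by MTT assay, with a stated time of 72 h (a higher number here means a weaker inhibitor, a lower number a stronger inhibitor), compound 1 (`COc1ccc(C(=O)N2CCN(CC(=O)N3CCN(CCCc4c[nH]c5ccc(OC)cc45)CC3)CC2)cc1`) gives 190000 nM as its reading. Compound 2 (`COc1cccc(C(=O)N2CCN(CC(=O)N3CCN(CCCc4c[nH]c5ccc(OC)cc45)CC3)CC2)c1`) returns only a limit, > 200000 nM as reported. Within the data shown here, compound 3 (`COc1ccc2[nH]cc(CCCN3CCN(C(=O)CN4CCN(C(=O)c5cccc(Br)c5)CC4)CC3)c2c1`) gives 105000 nM as its reading, which lies within the scatter of compound 1, the only other numeric value in the set.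

The next structure is compound 4 (`COc1ccc2[nH]cc(CCCN3CCN(C(=O)CN4CCN(C(=O)c5ccccc5Br)CC4)CC3)c2c1`), with 2-bromophenyl in place of 3-bromophenyl on a carbonyl carbon. Among the measured compounds shown here, no measured compound carries 2-bromophenyl. For the measured compounds named here, the nearest precedent is the methoxy shift, which gave an at least 1.0-fold higher number from compound 1 to compound 2 (0.02 log units; that floor lies within the scatter) for 3-methoxyphenyl in place of 4-methoxyphenyl. The exchanges of group gave a 1.8-fold lower number from compound 1 to compound 3 (0.26 log units; within the scatter) for 3-bromophenyl in place of 4-methoxyphenyl and an at least 1.9-fold lower number from compound 2 to compound 3 (0.27 log units; that floor lies within the scatter) for bromo in place of methoxy. None of these steps is shown beyond the scatter, and two of them are floors set by a limit. No step beyond the scatter is therefore expected in this assay and no direction is favoured. The expected step is a 1.1-fold higher number from compound 3 to compound 4 (0.04 log units; within the scatter) as a working estimate. A report of a limit alone remains possible. For compound 4 the estimated value is 115000 nM with an expected range of 60000 nM to 200000 nM in this series.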

Compound 4, half-maximal inhibitory concentration: 111000 nM
The estimate for compound 4 lay 1.0-fold (0.02 log units) above the measured number; the measured number falls inside the stated range.
By their numbers in this assay, from the lowest: compounds 3, 4 and 1 (each within the scatter of the next). At a limit, above all of these: compound 2.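

In this assay, among these compounds, shifting the bromo group gives a 1.1-fold higher number from compound 3 to compound 4 (0.02 log units; within the scatter) for 2-bromophenyl in place of 3-bromophenyl on the carbonyl carbon, the first comparison here of two bromo isomers, and it stays within the scatter. The 2-bromophenyl group also stays within the scatter of the methoxy compounds, with a 1.7-fold lower number from compound 1 to compound 4 (0.23 log units; within the scatter) and an at least 1.8-fold lower number from compound 2 to compound 4 (0.25 log units; that floor lies within the scatter), the second being only a floor, so no step shown at this carbonyl carbon goes beyond the scatter. Compound 2 remains the one reading in this set that is a limit and not a number: the limit of > 200000 nM in this assay, at which 1 of the 4 values shown sits.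

On these data alone, what stays open is whether any other group on this carbonyl carbon would give a step beyond the scatter, for instance an aminophenyl or carboxyphenyl group in place of the bromophenyl, or a phenyl group carried on a longer chain. As far as these compounds go, all four compounds also keep the shared core unchanged, and the effect of a change there on the reading in this assay remains untested in this set.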